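Sulfooxy Selenium Chains and the Assay Limit

The compounds below may be only part of what the source reports. "The series", "measured", "known", "first", "only" and "open" are said of these compounds alone.

Compound 1 `O=S(=O)(O)OCCCCCCCCCC[Se]c1ccccc1`: in a functional assay on HCT-116 cells (Homo sapiens) for cytotoxicity, read by MTT assay, with a stated time of 24 h (on this read-out higher numbers stand for weaker inhibition and lower numbers for stronger inhibition), compound 1 reaches the assay limit of > 100000 nM.
Compound 2 `O=S(=O)(O)OCCCCCCCCCC[Te]c1ccccc1`: in this assay compound 2 gives 7470 nM.
Compound 3 `O=S(=O)(O)OCCCCCCCCCCCC[Se]c1ccccc1`: in this assay compound 3 reaches the assay limit of > 100000 nM.

Compound 1 stands at a limit, not a number, in this assay; two of the three values shown sit there (the limit of > 100000 nM in this assay, at which 2 of the 3 values shown sit). Going by the values given here, only the step of an at least 13-fold lower number from compound 1 to compound 2 (1.12 log units; beyond the scatter) is readable, and it concerns the selenium-to-tellurium exchange, not the chain. The step that the two limits leave unreadable from compound 1 to compound 3 is the one that bears on the chain and it cannot be sized, since both ends are limits.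

Compound 4 `O=S(=O)(O)OCCCCCCCC[Se]c1ccccc1` differs from compound 1 by sulfooxy in place of 2-(sulfooxy)ethyl on a saturated chain carbon, eight bonds along the chain from a selenium atom. Among the compounds with values here, no measured step shows a chain change of this kind giving a number; the selenium compounds 1 and 3 both sit at the limit, and compound 2 alone, with tellurium, gives a number. Compound 4 keeps selenium, so the expectation is that it stays where compound 1 and compound 3 stand, with no step beyond the scatter, which is what a step that the limit leaves unreadable from compound 1 to compound 4 is meant to express. Compound 4 is therefore estimated at 150000 nM in this assay, with a range from 30000 nM to 600000 nM, most likely reported again only as a limit.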

Compound 4, half-maximal inhibitory concentration: > 100000 nM
Compound 4: only a limit was reported (the forecaster's own chance of this, stated with the estimate: 80%); the middle value is on the limit's open side.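

Compound 4, like compound 1, is reported only as a limit in this assay, so the step between them cannot be read and no new step arises: the limit of > 100000 nM in this assay, at which 3 of the 4 values shown sit.

The compounds shown leave open whether chain length changes the potency of compound 1, compound 3 and compound 4 below that limit, and whether it affects the tellurium compound 2.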